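The source may hold more compounds than are shown below. What is called first, only, known or untested is meant among the compounds shown, and "the series" means these compounds.

Measured so far in a functional assay for inhibition of sodium/hydrogen exchanger (Oryctolagus cuniculus); on this read-out higher numbers stand for weaker inhibition and lower numbers for stronger inhibition:
compound 1 `Cc1cc(F)c(S(C)(=O)=O)cc1C(=O)N=C(N)N`: 44 nM
compound 2 `Cc1cc(C)c(S(C)(=O)=O)cc1C(=O)N=C(N)N`: 11 nM
compound 3 `Cc1cc(OC2CCCC2)c(S(C)(=O)=O)cc1C(=O)N=C(N)N`: 27 nM

Compound 3 carries the second highest of the three numbers: the step of a 1.6-fold lower number from compound 1 to compound 3 (0.21 log units; within the scatter) lies within the scatter, whereas a 2.5-fold higher number from compound 2 to compound 3 (0.39 log units; beyond the scatter) lies beyond it. Compound 4 `Cc1cc(Nc2ncccn2)c(S(C)(=O)=O)cc1C(=O)N=C(N)N` is not yet measured. (pyrimidin-2-yl)amino in place of cyclopentyloxy on an aromatic carbon All three measured steps change the same aromatic carbon: a 4.0-fold lower number from compound 1 to compound 2 (0.60 log units; beyond the scatter) and a 2.5-fold higher number from compound 2 to compound 3 (0.39 log units; beyond the scatter) were modest, and a 1.6-fold lower number from compound 1 to compound 3 (0.21 log units; within the scatter) fell within the scatter. None of them involves a (pyrimidin-2-yl)amino group, so the direction of the new step is open; since the measured values occupy a narrow band, no step beyond the scatter is expected for a 1.1-fold higher number from compound 3 to compound 4 (0.05 log units; within the scatter). Compound 4 is therefore estimated at 30 nM in this assay, with a range of 10 nM to 90 nM.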

Compound 4, half-maximal inhibitory concentration: 8.3 nM
Beside the measured number, compound 4's estimate is 3.6-fold (0.56 log units) above it, outside the stated range (below it).
By their numbers in this assay, from the lowest: compounds 4 and 2 (each within the scatter of the next); then compounds 3 and 1 (each within the scatter of the next).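

In this assay the aromatic carbon ortho to a methylsulfonyl group accepts (pyrimidin-2-yl)amino with a 3.3-fold lower number from compound 3 to compound 4 (0.51 log units; beyond the scatter) and with a 5.3-fold lower number from compound 1 to compound 4 (0.72 log units; beyond the scatter) as well. With a 1.3-fold lower number from compound 2 to compound 4 (0.12 log units; within the scatter) there is no separation from methyl, so the rise seen with cyclopentyloxy does not extend to this ring-bearing group. No supporting data bear on why the two ring-bearing groups differ.

Still open, on these data alone, is whether the linking amino hydrogen or the ring nitrogens account for the step. A phenylamino group or a plain amine at this carbon would separate the two.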